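Trifluoromethoxy in Place of Trifluoromethyl: Tolerated Dose Outlook

The source may report more compounds than this note shows. Statements on the series, on what has been measured and on what is new or still open speak of the compounds shown alone.

Measured compounds:
compound 1 `Cc1ccc(CNN2CCN(c3nc(=O)c4cc(C(F)(F)F)cc([N+](=O)[O-])c4s3)CC2)cc1` gives > 64 ug/mL
compound 2 `CC(C)(C)c1ccc(CNN2CCN(c3nc(=O)c4cc(C(F)(F)F)cc([N+](=O)[O-])c4s3)CC2)cc1` gives > 64 ug/mL
compound 3 `O=c1nc(N2CCN(Nc3ccc(C(F)(F)F)cc3)CC2)sc2c([N+](=O)[O-])cc(C(F)(F)F)cc12` gives > 64 ug/mL

In an ADME assay on Vero cells (Chlorocebus sabaeus) for cytotoxicity, read by MTT assay, with a stated time of 72 h (a higher number here means that more compound is tolerated, a lower number that less compound is tolerated), compound 1 gives > 64 ug/mL, which is a limit of the assay and not a number. Compound 2 likewise gives > 64 ug/mL, a limit. Compound 3 gives > 64 ug/mL, again a limit. Compound 3 therefore stands where all three measured compounds sit, at the limit of > 64 ug/mL in this assay, at which 3 of the 3 values shown sit. The steps among them, a step that the two limits leave unreadable from compound 1 to compound 2, a step that the two limits leave unreadable from compound 1 to compound 3 and a step that the two limits leave unreadable from compound 2 to compound 3, cannot be read because each end is a limit.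

Compound 4 `O=c1nc(N2CCN(Nc3ccc(OC(F)(F)F)cc3)CC2)sc2c([N+](=O)[O-])cc(C(F)(F)F)cc12` differs from compound 3 by trifluoromethoxy in place of trifluoromethyl on an aromatic carbon. Going by the values given here, none of the measured steps gives a readable size for such a change, and all of them end at the limit. No step beyond the scatter is therefore expected in this assay from compound 3 to compound 4, and the step that the limit leaves unreadable from compound 3 to compound 4 is an estimate around no change. Compound 4 is expected to give about 80 ug/mL, within 40 ug/mL to 160 ug/mL, most likely again as a limit.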

Compound 4, half-maximal cytotoxic concentration: > 64 ug/mL
Compound 4: a limit, no number (the forecaster's own chance of this, stated with the estimate: 85%); the middle value is on the limit's open side.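

In this assay compound 4 gives > 64 ug/mL, a limit and not a number, so no step between compound 4 and compound 1, compound 2 or compound 3 can be read: the limit of > 64 ug/mL in this assay, at which 4 of the 4 values shown sit.

The compounds shown leave open at what concentration any of the four harms these cells, and so whether trifluoromethoxy in place of trifluoromethyl makes any difference here.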